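The source may hold more compounds than are shown below. What is called first, only, known or untested is meant among the compounds shown, and "the series" means these compounds.

Of the compounds shown here, three have been measured in a functional assay on CFPAC-1 cells (Homo sapiens) for antiproliferative activity, read by MTT assay, with a stated time of 72 h (a higher number here means a weaker inhibitor, a lower number a stronger inhibitor), and one more awaits the same test. Compound 2 `COc1ccccc1-c1cn(C[C@H](O)[C@H]2OC(=O)C(OCc3ccccc3)=C2OCc2ccccc2)nn1` carries a 2-methoxyphenyl on a five-membered aromatic ring with 3 nitrogen. In this assay compound 2 gives only a limit, > 100000 nM. Compound 1 `O=C1O[C@H]([C@@H](O)Cn2cc(-c3cccc(O)c3)nn2)C(OCc2ccccc2)=C1OCc1ccccc1` differs from compound 2 in a single place: 3-hydroxyphenyl in place of 2-methoxyphenyl on an aromatic carbon. In this assay compound 1 gives 54100 nM. The step of an at least 1.8-fold lower number from compound 2 to compound 1 (0.26 log units; that floor lies within the scatter) is therefore known only as a floor, because its starting point is the limit of > 100000 nM in this assay, at which 2 of the 3 values shown sit.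

Compound 3 `COc1ccccc1-c1cn(C/C=C2\OC(=O)C(OCc3ccccc3)=C2OCc2ccccc2)nn1` keeps the 2-methoxyphenyl but is built on a different core; the difference between the two cores is not broken down here. In this assay compound 3 gives only a limit, > 100000 nM.

Compound 4 `O=C1O/C(=C\Cn2cc(-c3cccc(O)c3)nn2)C(OCc2ccccc2)=C1OCc1ccccc1` stands to compound 3 as compound 1 stands to compound 2: 3-hydroxyphenyl in place of 2-methoxyphenyl on an aromatic carbon. The place of the change is described in the same words for both pairs, so it is the same change made on a second core. Because the earlier step was an at least 1.8-fold lower number from compound 2 to compound 1 (0.26 log units; that floor lies within the scatter), a similar shift is expected here, while the starting value of compound 3 being a limit leaves the size open. Compound 4 is expected to land near 70000 nM, most likely between 30000 nM and 150000 nM. The expected step from compound 3 to compound 4 is an at least 1.4-fold lower number from compound 3 to compound 4 (0.15 log units; that floor lies within the scatter), with a real chance that compound 4 also returns only a limit.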

Compound 4, half-maximal inhibitory concentration: 33700 nM
Compound 4: the middle estimate sits 2.1-fold (0.32 log units) above what was measured; the range from low to high includes it.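

In this assay, replacing 2-methoxyphenyl with 3-hydroxyphenyl on the second core gives an at least 2.9-fold lower number from compound 3 to compound 4 (0.47 log units; beyond the scatter), so on this core the lower number holds up even though only its floor is known. Set beside the same change on the first core, the result shows a shift in the same direction on both, but it does not show that the shift has the same size: the same change on two cores in this assay, an at least 1.8-fold lower number (0.26 log units; that floor lies within the scatter) from compound 2 to compound 1 and an at least 2.9-fold lower number (0.47 log units; beyond the scatter) from compound 3 to compound 4; the limit leaves it open whether they differ

Compound 2 and compound 3 each stand at a limit of the assay rather than at a number, so both steps are floors, and two cores are too few to make a rule for carrying this change across the series: the limit of > 100000 nM in this assay, at which 2 of the 4 values shown sit.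

The compounds shown leave open whether the lower number comes from the hydroxyl group itself or from where it sits on the phenyl ring, as well as from losing the methoxy group; a 3-methoxyphenyl and a 2-hydroxyphenyl on each core would help to separate these. Going by these compounds, it also remains open whether another group on the same phenyl ring, such as an amine or a carboxylic acid, would behave alike on both cores.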